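This account rests on a few compounds, and the source may have more. Where it says the series, first, only, none or still open, it means among the compounds named here.

Compound 1 `COc1ccc2nc(C)cc(OCC(=O)Nc3cccc(C)c3)c2c1` gives 39800 nM in a toxicity assay on HepG2 cells (Homo sapiens) for inhibition, read by CellTiter-Glo, with a stated time of 48 h; a lower number here means a stronger inhibitor, a higher number a weaker inhibitor.
Compound 2 `COc1cccc(NC(=O)COc2cc(C)nc3ccc(OC)cc23)c1` gives only a limit of the assay, > 100000 nM, in this assay.
Compound 3 `COc1ccc(NC(=O)COc2cc(C)nc3ccc(OC)cc23)cc1` likewise gives only a limit, > 100000 nM, in this assay.

Compound 3 therefore stands at the limit of the assay and no number is known for it, a situation it shares with compound 2, as the limit of > 100000 nM in this assay, at which 2 of the 3 values shown sit, records. Compound 4 `COc1ccc2nc(C)cc(OCC(=O)Nc3cc(C)c(F)c(C)c3)c2c1` differs from compound 3 by 4-fluoro-3,5-dimethylphenyl in place of 4-methoxyphenyl on an amide-type nitrogen. The step that bears on this change is an at least 2.5-fold higher number from compound 1 to compound 3 (0.40 log units; beyond the scatter), in which a methyl-bearing phenyl gave a number and a methoxyphenyl gave only a limit; the step that the two limits leave unreadable from compound 2 to compound 3 cannot be read. Since compound 4 carries methyl groups and a fluorine rather than a methoxy, a return to a readable number near that of compound 1 is expected, though the step of an at least 2.5-fold lower number from compound 3 to compound 4 (0.39 log units; beyond the scatter) can only be estimated from a limit. Compound 4 is therefore estimated at 40000 nM, between 12000 nM and 130000 nM.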

Compound 4, half-maximal inhibitory concentration: > 100000 nM
Compound 4: no number, only a limit; the forecaster's own chance of this, stated with the estimate: 35%; middle value at least 2.5-fold (0.39 log units) from the limit.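

Removing the methoxy is not enough to bring back a readable number in this assay: compound 4 has methyl groups and a fluorine on its phenyl ring, yet it gives only a limit. Among the groups shown on the amide-type nitrogen, only 3-methylphenyl gives a number, and the change to 4-fluoro-3,5-dimethylphenyl is an at least 2.5-fold higher number from compound 1 to compound 4 (0.40 log units; beyond the scatter). The steps from compound 2 and compound 3 to compound 4 join two limits and cannot be read.

As far as these compounds go, how far these compounds lie past the limit stays open. So does what a phenyl ring carrying an amine or a carboxylic acid would give on that nitrogen.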